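The compounds below may be only part of what the source reports. "The series", "measured", "known", "first", "only" and "open" are said of these compounds alone.

For the measured compounds named here, compound 1 (`CCN1CCN(c2ccc(S(=O)(=O)Oc3cccc(Br)c3)cc2)C1=O`) gives 2500 nM in a functional assay on MCF7 cells (Homo sapiens) for antiproliferative activity, read by sulforhodamine B assay, with a stated time of 48 h (on this read-out higher numbers stand for weaker inhibition and lower numbers for stronger inhibition), and holds the only true number so far. Compound 2 (`CCN1CCN(c2ccc(S(=O)(=O)Oc3ccc(OC)cc3)cc2)C1=O`) reads > 100000 nM as a limit of the assay and not a number.

Compound 3 (`CCCCN1CCN(c2ccc(S(=O)(=O)Oc3cccc(Br)c3)cc2)C1=O`) comes next, and the change from compound 1 is ethyl in place of hydrogen on a saturated chain carbon, two bonds along the chain from an amide-type nitrogen in a ring in the form of ethyl in place of hydrogen on a saturated chain carbon, two bonds along the chain from an amide-type nitrogen in a ring. Read one bond further out, this is ethyl to butyl.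

Going by the values given here, the only measured step is an at least 40-fold higher number from compound 1 to compound 2 (1.60 log units; beyond the scatter) and it is large. It sits at a different place, where 4-methoxyphenyl takes the place of 3-bromophenyl on an oxygen, so it bears on compound 3 only indirectly. Among the compounds with values here, no measured step touches the chain. Within the data shown here, no large step is therefore expected in this assay, and the direction stays open.

The expected step is a 1.3-fold lower number from compound 1 to compound 3 (0.10 log units; within the scatter) and it carries a wide margin. Compound 3 is estimated at 2000 nM with a range of 600 nM to 7000 nM as a working figure.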

Compound 3, half-maximal inhibitory concentration: 85 nM
The estimate for compound 3 lay 24-fold (1.37 log units) above the measured number, outside the stated range (below it).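

The chain on the amide-type nitrogen in a ring proves to be a sensitive position in this assay: ethyl to butyl gives a 29-fold lower number from compound 1 to compound 3 (1.47 log units; beyond the scatter). Compound 3 keeps the 3-bromophenyl on an oxygen of compound 1, so this step belongs to the chain alone, and the series now has a second place, besides the group on that oxygen, where a single change moves the number beyond the scatter. No measurement at hand accounts for the size of this step, which stands as an observation without a cause.

As far as these compounds go, whether the number keeps falling with a longer chain such as hexyl, or whether a chain ending in an amine or a carboxylic acid holds the level of compound 3, stays open, as a single chain change fixes no trend. For the compounds shown here, equally open is whether butyl has the same effect when 4-methoxyphenyl sits on the oxygen, as that group has been seen only with ethyl, in compound 2.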